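The source may report more compounds than this note shows. Statements on the series, on what has been measured and on what is new or still open speak of the compounds shown alone.

Of the compounds shown here, three have so far been tested in a functional assay on HCT-15 cells (Homo sapiens) for cytotoxicity, read by MTT assay, with a stated time of 2 days; on this read-out higher numbers stand for weaker inhibition and lower numbers for stronger inhibition. In this test, compound 1 (`Cc1cccc(-c2nc3cc(C)ccc3c(=O)[nH]2)c1`) gives 21100 nM, while compound 2 (`CCN(CC)c1ccc2nc(-c3ccccc3N(C)C)[nH]c(=O)c2c1`) gives 4200 nM. Compound 3 (`Cc1ccc2nc(-c3cccc(C(F)(F)F)c3)[nH]c(=O)c2c1`) has no exact number and is reported only as a limit, > 50000 nM. This makes it the one case among the three of the limit of > 50000 nM in this assay, at which 1 of the 3 values shown sits.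

Compound 4 (`Cc1ccc2nc(-c3cccc(OC(F)(F)F)c3)[nH]c(=O)c2c1`) is compound 3 with a single change: trifluoromethoxy in place of trifluoromethyl on an aromatic carbon of a six-membered aromatic ring of carbon only. The counted difference is trifluoromethoxy in place of trifluoromethyl on an aromatic carbon. The rest of the structure stays the same, so any change in the result would come from this swap.

Among the compounds with values here, no two measured compounds differ in only one place, so the data give no direct guide to the size of this step. In this assay, the expectation is therefore a small step with no firm direction, probably none beyond the usual scatter. The expected change is an at least 1.1-fold lower number from compound 3 to compound 4 (0.07 log units; that floor lies within the scatter). Compound 4 may well be reported only as a limit too. For compound 4 the estimated value is 42000 nM, with an expected range of 15000 nM to 90000 nM.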

Compound 4, half-maximal inhibitory concentration: > 50000 nM
Compound 4: only a limit was reported; the forecaster's own chance of this, stated with the estimate: 55%; middle value at least 1.1-fold (0.07 log units) away from the limit.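

In this assay compound 3 and compound 4 are both reported only as a limit, so no step can be read between them for trifluoromethoxy in place of trifluoromethyl: the limit of > 50000 nM in this assay, at which 2 of the 4 values shown sit.

The compounds shown leave open whether this swap changes the result at all, and what exact number either compound would give.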